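A few compounds are considered here, and "the series" means these few. Any claim that something is new, unique, unknown or untested is made for them only; others in the source may bear on it.

Compound 3 `Cn1c(=O)c(C(=O)Nc2ccc(Oc3ccncc3-c3cccnc3)c(F)c2)nn(-c2cccc(C(F)(F)F)c2)c1=O` carries a 3-(trifluoromethyl)phenyl group on an aromatic nitrogen of its core. In a functional assay on A549 cells (Homo sapiens) for cytotoxicity, read by MTT assay, with a stated time of 72 h (on this read-out higher numbers stand for weaker inhibition and lower numbers for stronger inhibition), compound 3 gives 460 nM, which is the smallest of the three numbers obtained so far. Compound 2 `Cn1c(=O)c(C(=O)Nc2ccc(Oc3ccncc3-c3cccnc3)c(F)c2)nn(-c2ccccc2F)c1=O` differs only by a 2-fluorophenyl group at that nitrogen, and in this assay compound 2 gives 610 nM; the step of a 1.3-fold lower number from compound 2 to compound 3 (0.12 log units; within the scatter) stays within the scatter. Compound 1 `Fc1ccc(Nc2cc(Nc3ccc(Oc4ccncc4-c4cccnc4)c(F)c3)ncn2)cc1F` has a different core, and in this assay compound 1 gives 7630 nM, far beyond the scatter from compound 3.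

Compound 4 `COc1ccc(-n2nc(C(=O)Nc3ccc(Oc4ccncc4-c4cccnc4)c(F)c3)c(=O)n(C)c2=O)c(OC)c1` is the next candidate. Its change from compound 3 is 2,4-dimethoxyphenyl in place of 3-(trifluoromethyl)phenyl on an aromatic nitrogen. For the measured compounds named here, the only step that bears on this position is the one from compound 2 to compound 3, and it was small. Going by the values given here, with only one such step in view, the expected shift in this assay is a 1.4-fold higher number from compound 3 to compound 4 (0.15 log units; within the scatter), that is, none clearly beyond the scatter, perhaps a slightly higher number. In this assay compound 4 is therefore estimated at 650 nM, with a range from 250 nM to 1700 nM.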

Compound 4, half-maximal inhibitory concentration: 890 nM
Compound 4: the middle estimate sits 1.4-fold (0.14 log units) below what was measured; the range from low to high includes it.
By their numbers in this assay, from the lowest: compounds 3, 2 and 4 (each within the scatter of the next); then compound 1.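

In this assay, 2,4-dimethoxyphenyl in place of 3-(trifluoromethyl)phenyl gives a 1.9-fold higher number from compound 3 to compound 4 (0.29 log units; within the scatter), and in place of 2-fluorophenyl it gives a 1.5-fold higher number from compound 2 to compound 4 (0.16 log units; within the scatter). For the compounds shown here, the earlier step at this nitrogen joined only two fluorine-bearing phenyl groups, whereas these two steps show that a phenyl group carrying two methoxy groups, with 2 hydrogen-bond acceptors where the group it replaces has 0, also stays within the scatter of both. Nothing available here gives a reason for this result.

The compounds shown leave open whether a group with no phenyl ring at this nitrogen, such as a longer alkyl chain, would take the number beyond the scatter. The same question stands for a phenyl group carrying an amine or a carboxylic acid.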